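The compounds below may be only part of what the source reports. "The series", "measured", "known", "first", "only" and "open" are said of these compounds alone.

Measured so far:
compound 1 `C/C(=N\O)c1nc2ccccc2s1`: > 100000 nM
compound 2 `O/N=C(\c1nnc(C(F)(F)F)s1)c1nc2ccccc2s1`: 15600 nM

In an ADME assay on CHO cells (Cricetulus griseus) for cytotoxicity (on this read-out higher numbers stand for weaker inhibition and lower numbers for stronger inhibition), compound 1 has only a limit, not a number: the limit of > 100000 nM in this assay, at which 1 of the 2 values shown sits. Compound 2, in this assay, gives 15600 nM. Compound 3 `O/N=C(\c1ccccc1)c1nc2ccccc2s1` is not yet measured. It differs from compound 1 in one place: phenyl in place of methyl on a carbon with a double bond to nitrogen. Going by the values given here, no measured pair shows this exact change. The move is expected to strengthen inhibition in this assay by an at least 3.3-fold lower number from compound 1 to compound 3 (0.52 log units; beyond the scatter), giving a number rather than a limit. Compound 3 is therefore estimated at 30000 nM in this assay, with a range from 8000 nM to 120000 nM.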

Compound 3, half-maximal inhibitory concentration: > 100000 nM
Compound 3 ended at the assay's limit (the forecaster's own chance of this, stated with the estimate: 30%); at least 3.3-fold (0.52 log units) between middle value and limit.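

Going by these compounds alone, compound 1 and compound 3 both give only a limit, not a number, in this assay, so no step between them can be read: the limit of > 100000 nM in this assay, at which 2 of the 3 values shown sit. The compounds shown leave open whether phenyl in place of methyl changes inhibition at all.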